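Hemolysis Readings and a Chloro-to-Hydrogen Step

A few compounds are considered here, and "the series" means these few. Any claim that something is new, unique, unknown or untested is made for them only; others in the source may bear on it.

Measured so far:
compound 1, `N=C(N)c1ccc(-c2ccc(-c3ccc(F)cc3)o2)o1`: 90%
compound 2, `N=C(N)c1ccc(-c2ccc(-c3ccc(Cl)cc3)s2)s1`: 81.7%

In an ADME assay on cells (Erythrocyte, Homo sapiens) for activation, read by hemolysis, with a stated time of 30 min, tested at 10 mM (a lower number here means a weaker effect, a higher number a stronger effect of the compound at the concentration tested), compound 1 gives 90% and compound 2 gives 81.7%. The gap between compound 2 and compound 1 lies within the scatter, so neither stands apart from the other on these two numbers.

Compound 3, `N=C(N)c1ccc(-c2ccc(-c3ccccc3)s2)s1`, differs from compound 2 by hydrogen in place of chloro on an aromatic carbon. For the measured compounds named here, no measured pair shows such a change, so the expected step from compound 2 to compound 3 in this assay is estimated as small and downward, roughly a number 7.7 percentage points lower from compound 2 to compound 3 (within the scatter), and may well stay within the scatter. Compound 3 is therefore expected to give about 74%, within a range of 52% to 92%.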

Compound 3, a percentage reported as activity, at one concentration (the size of the read-out at that concentration, not a potency): 85.1%
The estimate for compound 3 lay 11.1 percentage points below the measured number; low and high end bracket the measured number.
By their numbers in this assay, from the lowest: compounds 2, 3 and 1 (each within the scatter of the next).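

With hydrogen in place of chloro on an aromatic carbon para to a large group, the step is a number 3.4 percentage points higher from compound 2 to compound 3 (within the scatter) in this assay on this measure. This first pair differing in one place shows that, on the core of compound 2, the hemolysis reading does not rest on the chloro group. Nothing at hand explains this reading.
Still open, from the compounds shown here alone, is whether an amine, a methoxy group or a carboxylic acid at this position would leave the reading within the scatter. Also open, going by these compounds, is whether the same exchange would give a similar step on the core of compound 1.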